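The source may hold more compounds than are shown below. What is called first, only, known or untested is meant among the compounds shown, and "the series" means these compounds.

Compound 1, with the structure `OC[C@H](NC[C@H]1NC[C@H](O)[C@@H]1O)c1ccc(-c2ccccc2)cc1`, is the starting point. In a functional assay on PC-3 cells (Homo sapiens) for cytotoxicity, read by colorimetric assay, with a stated time of 72 h (on this read-out lower numbers stand for stronger inhibition and higher numbers for weaker inhibition), compound 1 reaches only a limit, > 200000 nM, so for it no number is known, only that it sits at the limit of > 200000 nM in this assay, at which 1 of the 2 values shown sits. Within the data shown here, the one related compound with a number is compound 2, `OC[C@H](NC[C@H]1NC[C@H](O)[C@@H]1O)c1ccc(-c2ccc(C(F)(F)F)cc2)cc1`, which in this assay gives 132000 nM. That change, trifluoromethyl in place of hydrogen on an aromatic carbon, gives an at least 1.5-fold lower number from compound 1 to compound 2 (0.18 log units; that floor lies within the scatter), and this floor is not large enough to be told apart from repeat scatter.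

The compound still to be measured is compound 3, `OC[C@H](NC[C@H]1NC[C@H](O)[C@@H]1O)c1ccc(-c2ccsc2)cc1`. Its difference from compound 1 is thiophen-3-yl in place of phenyl on an aromatic carbon. Among the measured compounds shown here, no measured step exchanges the phenyl ring itself, so the only step that bears on it is the one from compound 1 to compound 2, whose floor lies within the scatter. The expectation is therefore a step of about a number no higher from compound 1 to compound 3 (the limit leaves the size open), that is no clear shift, with a fair chance that compound 3 again returns only a limit. The estimate for compound 3 in this assay is 200000 nM, between 80000 nM and 500000 nM.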

Compound 3, half-maximal inhibitory concentration: "not active" (no number reported)
Nothing numeric was reported for compound 3, and the estimate cannot be compared.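

Among these compounds, compound 3 is reported only as not active, with no number, so no step from compound 1 to compound 3 can be read in this assay. Compound 1 itself has only a limit: the limit of > 200000 nM in this assay, at which 1 of the 3 values shown sits.

The compounds shown leave open how far, if at all, thiophen-3-yl in place of phenyl changes the cytotoxicity read-out.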